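The source may hold more compounds than are shown below. What is called first, only, known or untested is meant among the compounds shown, and "the series" means these compounds.

Measured so far:
compound 1 `C=CC(=C)CC[C@@H]1[C@@]2(C)CCC[C@](C)(COC(=O)/C=C/c3ccc(O)cc3)[C@@H]2CC[C@@]1(C)O`: 11800 nM
compound 2 `C=C[C@@](C)(O)CC[C@H]1C(=C)CC[C@@H]2[C@]1(C)CCC[C@]2(C)C(=O)O`: > 40000 nM
compound 3 `C=C1CC[C@@H]2[C@](C)(CCC[C@@]2(C)C(=O)O)[C@H]1CC/C(C)=C/COC(C)=O`: > 40000 nM

In a functional assay on HL-60 cells (Homo sapiens) for cytotoxicity, read by MTT assay, with a stated time of 48 h (on this read-out higher numbers stand for weaker inhibition and lower numbers for stronger inhibition), compound 1 gives 11800 nM. Compound 2 is reported only as a limit of this assay, > 40000 nM. Compound 3 likewise reaches only a limit, > 40000 nM. Compound 2 therefore stands at the limit of > 40000 nM in this assay, at which 2 of the 3 values shown sit, and no number separates it from compound 3; compound 1 alone carries a measured value in this assay. Among the compounds with values here, no two measured compounds differ in a single place, so no measured step exists in the set.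

Compound 4 `C=C1CC[C@@H]2[C@](C)(CCC[C@]2(C)C(=O)O)[C@H]1C/C=C(\C)C=O` differs from compound 2 by 2-formylprop-1-en-1-yl in place of 2-hydroxy-2-methylbut-3-en-1-yl on a saturated chain carbon bound to a saturated ring carbon. Within the data shown here, with no measured step to lean on, the expectation for this assay is a move of modest size toward stronger inhibition from the limit of compound 2, while a result that again comes back only as a limit remains a real possibility. Compound 4 is expected at 20000 nM, within 6000 nM to 60000 nM. The step this implies, an at least 2.0-fold lower number from compound 2 to compound 4 (0.30 log units; that floor lies within the scatter), is an estimate and not a measurement.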

Compound 4, half-maximal inhibitory concentration: > 40000 nM
Compound 4: a limit, no number; the forecaster's own chance of this, stated with the estimate: 35%; middle value at least 2.0-fold (0.30 log units) from the limit.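

Within the data shown here, compound 2 and compound 4 both come back only as a limit, and no step between them can be read: the limit of > 40000 nM in this assay, at which 3 of the 4 values shown sit. On these data alone, whether 2-formylprop-1-en-1-yl in place of 2-hydroxy-2-methylbut-3-en-1-yl changes the read-out in this assay at all remains open.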